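Bromine in Place of Trifluoromethyl on Compound 1

The compounds below may be only part of what the source reports. "The series", "measured", "known", "first", "only" and "open" are said of these compounds alone.

Among the compounds with values here, compound 1 `O=[N+]([O-])c1cccc(CNc2cc(C(F)(F)F)cc3[nH]ncc23)c1` is the strongest of the three compounds measured so far: in an assay for inhibition of Indoleamine 2,3-dioxygenase 1 (Homo sapiens), with stated times of 10 min and 60 min, tested at 100 uM (a lower number here means a weaker effect, a higher number a stronger effect of the compound at the concentration tested), compound 1 gives 69%. Compound 2 `O=C(O)CNc1cccc(CNc2cc(C(F)(F)F)cc3[nH]ncc23)c1` gives 8% in this assay, and compound 3 `CNC(=O)c1cccc(CNc2cc(C(F)(F)F)cc3[nH]ncc23)c1` gives 46%. The measured steps are a number 61 percentage points lower from compound 1 to compound 2 (beyond the scatter), a number 23 percentage points lower from compound 1 to compound 3 (beyond the scatter) and a number 38 percentage points higher from compound 2 to compound 3 (beyond the scatter). Every one of these steps replaces the nitro group or its successor, and the trifluoromethyl group stays untouched throughout.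

Compound 4 `O=[N+]([O-])c1cccc(CNc2cc(Br)cc3[nH]ncc23)c1` keeps the nitro group of compound 1 and changes the other end: bromo in place of trifluoromethyl on an aromatic carbon. Within the data shown here, none of the measured steps bears on this position, so nothing shows how this assay responds to a change there. With the nitro group that accompanies the strongest number retained, the step from compound 1 is expected to be small, on the order of a number 9 percentage points lower from compound 1 to compound 4 (within the scatter), in no definite direction. Compound 4 is therefore estimated at 60%, with a range from 35% to 85%.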

Compound 4, a percentage reported as inhibition, at one concentration (the size of the read-out at that concentration, not a potency): 95%
For compound 4 the middle estimate is 35 percentage points below the measured one; measured number above the stated range.
By their numbers in this assay, from the lowest: compound 2; then compound 3; then compound 1; then compound 4.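

The position that holds trifluoromethyl, unchanged in compound 1, compound 2 and compound 3, proves able to shift the read-out in this assay: with the nitro group held constant, bromo in place of trifluoromethyl gives a number 26 percentage points higher from compound 1 to compound 4 (beyond the scatter). A single bromine atom thus does more here than the four heavy atoms it replaces, although neither group counts a hydrogen-bond donor, a hydrogen-bond acceptor or a net charge. No measurement at hand accounts for this gain.

On these data alone, whether bromo would raise the number in the same way alongside the methylcarbamoyl group of compound 3 or the (carboxymethyl)amino group of compound 2 remains open. Also open, as far as these compounds go, is how chlorine, a methyl group, a nitrile or an amine would read at this position on the aromatic carbon.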